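Sulfur substituent change in a pyridylbenzyl-aminopyrazolopyrimidine series

A few compounds are considered here, and "the series" means these few. Any claim that something is new, unique, unknown or untested is made for them only; others in the source may bear on it.

Measured so far:
compound 1 `CC(C)c1n[nH]c2c(NCc3ccc(-c4ccccn4)cc3)nc(SC(CO)C(C)C)nc12`, 980 nM in a functional assay on HT cells (Homo sapiens) for antiproliferative activity, read by fluorescence, with a stated time of 72 h; a lower number here means a stronger inhibitor of growth, a higher number a weaker inhibitor of growth
compound 2 `CC(C)c1n[nH]c2c(NCc3ccc(-c4ccccn4)cc3)nc(SC3CCCCC3O)nc12`, 636 nM

Compound 1 gives the highest of the two numbers measured in this assay; its nearest neighbour is compound 2, and the gap a 1.5-fold lower number from compound 1 to compound 2 (0.19 log units; within the scatter) is within the scatter. Going by the values given here, that single step swaps one group on the sulfur for another, and it is the only measured step.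

Compound 3 `COCSc1nc(NCc2ccc(-c3ccccn3)cc2)c2[nH]nc(C(C)C)c2n1` is the next compound to be measured in this assay. Relative to compound 1 its structure differs at the sulfur: methoxymethyl in place of 1-(hydroxymethyl)-2-methylpropyl on a sulfur. The measured step from compound 1 to compound 2 bears on it only loosely, since that step exchanged one substituent on the sulfur for another of similar size, whereas here the entering group is markedly smaller and of a different kind. What the data show is that a change on the sulfur moved the number no more than a 1.5-fold lower number from compound 1 to compound 2 (0.19 log units; within the scatter), so a step of modest size is expected here, most likely toward a somewhat higher number, but possibly none beyond the scatter. For compound 3 the estimated step is a 1.4-fold higher number from compound 1 to compound 3 (0.15 log units; within the scatter). Compound 3 is therefore expected to give 1400 nM in this assay, within the range 500 nM to 4000 nM.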

Compound 3, concentration for 50% growth inhibition: 340 nM
Compound 3: the middle estimate sits 4.1-fold (0.61 log units) above what was measured; measured number outside the range, below it.
By their numbers in this assay, from the lowest: compounds 3, 2 and 1 (each within the scatter of the next, the first and the last beyond it).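

In this assay, going by these compounds alone, the step of a 2.9-fold lower number from compound 1 to compound 3 (0.46 log units; beyond the scatter) is the first change on the sulfur that lies beyond the scatter, and it comes with methoxymethyl, which carries fewer heavy atoms and no hydrogen-bond donor, entering in place of 1-(hydroxymethyl)-2-methylpropyl. Measured against the ring-bearing 2-hydroxycyclohexyl group, methoxymethyl cannot be separated from it, with the step of a 1.9-fold lower number from compound 2 to compound 3 (0.27 log units; within the scatter) remaining within the usual variation. Across these three compounds, then, neither a ring nor a hydrogen-bond donor on the sulfur substituent is required for a number in this range, and the larger open-chain 1-(hydroxymethyl)-2-methylpropyl group of compound 1 is the only one that separates from any other, and only from methoxymethyl.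

No measurement available here explains the step from compound 1 to compound 3. Still open, as far as these compounds go, is whether the oxygen of methoxymethyl contributes at all, which a plain ethyl chain on the sulfur would test, and how an amine, a carboxylic acid or a longer alkoxyalkyl chain at the same place would compare.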